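Replacing 1,3-Thiazol-4-yl with 4H-1,2,4-Triazol-4-yl

The compounds below may be only part of what the source reports. "The series", "measured", "known", "first", "only" and "open" are said of these compounds alone.

Compound 1 `O=C(O)c1cc(-c2cncs2)ccc1O` in a functional assay on the whole organism for inhibition, with Rattus norvegicus as the target, read by paw edema (a higher number here means that more compound is needed for the effect, a lower number that less compound is needed), gives only a limit of the assay, > 200 mg/kg.
Compound 2 `O=C(O)c1cc(-n2nccn2)ccc1O` in this assay gives 150 mg/kg.
Compound 3 `O=C(O)c1cc(-c2cscn2)ccc1O` in this assay gives 95 mg/kg.

Of the two numbers that are not limits, compound 3 and compound 2 sit within the scatter of each other, as the step of a 1.6-fold lower number from compound 2 to compound 3 (0.20 log units; within the scatter) shows, so neither can be placed ahead of the other. For compound 1 only a limit is known (the limit of > 200 mg/kg in this assay, at which 1 of the 3 values shown sits), so the step of an at least 2.1-fold lower number from compound 1 to compound 3 (0.32 log units; beyond the scatter) is a floor rather than a measured size. Compound 4 `O=C(O)c1cc(-n2cnnc2)ccc1O` differs from compound 3 in one place: 4H-1,2,4-triazol-4-yl in place of 1,3-thiazol-4-yl on an aromatic carbon. Among the compounds with values here, two measured steps bear on this change. The step of a 1.6-fold lower number from compound 2 to compound 3 (0.20 log units; within the scatter) exchanged a different triazole for the ring now being removed and stayed within the scatter; the step of an at least 1.3-fold lower number from compound 1 to compound 2 (0.12 log units; that floor lies within the scatter) also compared a triazole with a thiazole and did not clearly go beyond it. Both suggest that a triazole in place of the 1,3-thiazol-4-yl of compound 3 changes little. For compound 4 the expected result is therefore 130 mg/kg, an estimated step of a 1.4-fold higher number from compound 3 to compound 4 (0.14 log units; within the scatter) that should not exceed the scatter, with a range from 70 mg/kg to 250 mg/kg.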

Compound 4, dose for half-maximal effect: > 250 mg/kg
Compound 4 ended at the assay's limit (the forecaster's own chance of this, stated with the estimate: 15%); at least 1.9-fold (0.28 log units) between middle value and limit.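

Placing 4H-1,2,4-triazol-4-yl on the aromatic carbon meta to a carboxy group and para to a hydroxy group gives an at least 2.6-fold higher number from compound 3 to compound 4 (0.42 log units; beyond the scatter) and so shows that a triazole cannot always replace the 1,3-thiazol-4-yl of compound 3 with little change. The two triazoles, however, cannot yet be told apart: the comparison gives an at least 1.6-fold higher number from compound 2 to compound 4 (0.22 log units; that floor lies within the scatter) in this assay and its floor does not clear the scatter. For compound 4 the result is a limit and not a number: the limit of > 250 mg/kg in this assay, at which 1 of the 4 values shown sits.

The step between compound 1 and compound 4 cannot be read, since two limits leave its size open. Going by these compounds, it also remains open whether a plain phenyl ring or an amine at this place would read closer to compound 3 or to compound 4.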